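A methyl added to the fluorophenyl: solubility of compound 4

The source may report more compounds than this note shows. Statements on the series, on what has been measured and on what is new or still open speak of the compounds shown alone.

In a physicochemical assay for solubility, read by HPLC, using the shake flask method, measured as kinetic solubility, with a stated time of 2 h, at pH 7.4 (on this read-out higher numbers stand for higher solubility and lower numbers for lower solubility), compound 3 `Cc1cc(NCc2ccccn2)n2ncc(-c3cccc(F)c3)c2n1` gives 5000 nM. Compound 1 `Cc1cc(NCCCc2ccccn2)n2nc(C)c(-c3ccccc3)c2n1` gives 5900 nM in this assay, which sits within the scatter of compound 3, while compound 2 `Cc1cc(NCc2c[nH]cn2)n2nc(C)c(-c3ccccc3)c2n1` gives 14600 nM, a number beyond the scatter above compound 3. Going by the values given here, the only measured step, a 2.5-fold higher number from compound 1 to compound 2 (0.39 log units; beyond the scatter), changes the group on the saturated chain carbon bound to the ring nitrogen, not the aryl ring on the fused system, so it bears only loosely on the present change. Compound 4 `Cc1cc(NCc2ccccn2)n2ncc(-c3ccc(F)cc3C)c2n1` differs from compound 3 by 4-fluoro-2-methylphenyl in place of 3-fluorophenyl on an aromatic carbon. Among the compounds with values here, with no measured step at that position, a change within the scatter is expected, leaning slightly downward with the added carbon. Compound 4 is therefore expected to give 3500 nM in this assay, within 1500 nM to 9000 nM, a step of a 1.4-fold lower number from compound 3 to compound 4 (0.15 log units; within the scatter).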

Compound 4, solubility: 42300 nM
For compound 4 the middle estimate is 12-fold (1.08 log units) below the measured one; the measured number lies above the stated range.
By their numbers in this assay, from the lowest: compounds 3 and 1 (each within the scatter of the next); then compound 2; then compound 4.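

In this assay the aryl group on the aromatic carbon of the five-membered ring proves able to move the read-out, with an 8.5-fold higher number from compound 3 to compound 4 (0.93 log units; beyond the scatter) on going from 3-fluorophenyl to 4-fluoro-2-methylphenyl. The earlier compounds shown here held no step at this position, and here the number rises although the entering group carries one more carbon. Nothing measured here accounts for that rise. The step changes both the methyl and the place of the fluorine, so the compounds shown do not separate the two. On these data alone, whether 4-fluorophenyl, 2-methylphenyl or a methoxy-bearing phenyl would give a similar number remains open.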